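Restoring an aryl group on the amine-bearing carbon

The source may report more compounds than this note shows. Statements on the series, on what has been measured and on what is new or still open speak of the compounds shown alone.

Compound 2: `CNCc1c(OC)cc(Oc2cccc(Nc3ccccc3)c2)cc1OC`, 11900 nM
Compound 1: `COc1cc(Oc2cccc(Nc3ccccc3)c2)cc(OC)c1CNCc1ccccc1`, 5220 nM
Compound 3: `COc1cc(Oc2cccc(Nc3ccccc3)c2)cc(OC)c1CNCc1ccc(C)cc1`, not yet measured

In a functional assay on DLD-1 cells (Homo sapiens) for inhibition, read by MTT assay, with a stated time of 72 h (on this read-out higher numbers stand for weaker inhibition and lower numbers for stronger inhibition), compound 2 gives 11900 nM, the highest of the two numbers; compound 1 gives 5220 nM. Compound 3 differs from compound 2 by 4-methylphenyl in place of hydrogen on a saturated chain carbon bound to an amine nitrogen. Among the measured compounds shown here, the one step that bears on this change is a 2.3-fold higher number from compound 1 to compound 2 (0.36 log units; beyond the scatter), which removed a phenyl at the same place. Putting an aryl group back is therefore expected to reverse that step, giving a number lower than that of compound 2 by a 2.4-fold lower number from compound 2 to compound 3 (0.38 log units; beyond the scatter) in this assay. Compound 3 is thus estimated at 5000 nM, within 2000 nM to 12000 nM.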

Compound 3, half-maximal inhibitory concentration: 6080 nM
Estimate against measurement, compound 3: 1.2-fold (0.08 log units) below; measured number inside the range.
By their numbers in this assay, from the lowest: compounds 1, 3 and 2 (each within the scatter of the next, the first and the last beyond it).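

In this assay, the 4-methylphenyl group gives a 2.0-fold lower number from compound 2 to compound 3 (0.29 log units; within the scatter), so on its own this change cannot be separated from compound 2, although the phenyl of compound 1 could be. Methyl on the aromatic carbon gives a 1.2-fold higher number from compound 1 to compound 3 (0.07 log units; within the scatter), so the shown data detect no difference between these two aryl groups at this position. Nothing measured here explains these numbers. From the compounds shown here alone, whether fluorine or a carboxylic acid in place of that methyl would change the number stays open. So does whether cyclohexyl could stand in place of the 4-methylphenyl.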